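Fluoro for chloro at two different places in one series

A few compounds are considered here, and "the series" means these few. Any claim that something is new, unique, unknown or untested is made for them only; others in the source may bear on it.

Compound 1 `O=C(O)CN1C(=O)/C(=C/c2nc3ccccc3n2Cc2ccc(F)cc2)SC1=S` and compound 2 `O=C(O)CN1C(=O)/C(=C/c2nc3ccccc3n2Cc2ccc(Cl)cc2)SC1=S` share one core. In a functional assay on Raji cells (Homo sapiens) for cytotoxicity, read by MTT assay, with a stated time of 48 h (a higher number here means a weaker inhibitor, a lower number a stronger inhibitor), compound 1 gives 1770 nM and compound 2 gives 11400 nM; the change fluoro in place of chloro on an aromatic carbon brings a 6.4-fold lower number from compound 2 to compound 1 (0.81 log units; beyond the scatter). Compound 3 `Cc1ccc(Cn2c(/C=C3\SC(=S)N(CC(=O)O)C3=O)nc3cc(Cl)ccc32)cc1` gives 20900 nM in this assay; the difference between its core and that of compound 2 is not broken down here. Compound 4 `Cc1ccc(Cn2c(/C=C3\SC(=S)N(CC(=O)O)C3=O)nc3cc(F)ccc32)cc1` is not yet measured. From compound 3 to compound 4 the change is fluoro in place of chloro on an aromatic carbon, the same kind of change as from compound 2 to compound 1, but on a ring that is part of a fused or bridged system of two rings, meta to a fused ring and para to a fused ring, rather than para to a large group. Because the earlier step of a 6.4-fold lower number from compound 2 to compound 1 (0.81 log units; beyond the scatter) sat at another place, only a smaller step is expected for compound 4, a 2.3-fold lower number from compound 3 to compound 4 (0.37 log units; beyond the scatter). Compound 4 is therefore estimated at 9000 nM, between 3000 nM and 25000 nM.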

Compound 4, half-maximal inhibitory concentration: 3280 nM
Beside the measured number, compound 4's estimate is 2.7-fold (0.44 log units) above it; measured number inside the range.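

In this assay, fluoro in place of chloro on an aromatic carbon brings a 6.4-fold lower number from compound 3 to compound 4 (0.80 log units; beyond the scatter), and the step keeps its size across the two cores: the same change on two cores in this assay, a 6.4-fold lower number (0.81 log units; beyond the scatter) from compound 2 to compound 1 and a 6.4-fold lower number (0.80 log units; beyond the scatter) from compound 3 to compound 4, 1.0-fold (0.00 log units) apart, within the scatter of two such steps Within these two pairs, the change therefore carries over from one core to the other, even though it sits at a different place in each. Two pairs do not make a rule for other cores or other places, and they give no reason for the size of the step.

Open, going by these compounds, is whether bromo or a methoxy group at these same places would also track across both cores. Also open, on these data alone, is how an amide in place of the carboxylic acid would affect the step.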